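The source may report more compounds than this note shows. Statements on the series, on what has been measured and on what is new or still open speak of the compounds shown alone.

Measured so far in this series:

compound 1, `COCc1cc(COc2ccc([C@]3(N)CCN([C@H](CC(C)C)C(=O)NO)C3=O)cc2)c2ccccc2n1` — 1160 nM
compound 2, `Cc1cc(COc2ccc([C@]3(N)CCN([C@H](CC(C)C)C(=O)NO)C3=O)cc2)c2ccccc2n1` — 389 nM

Among the compounds with values here, compound 2 carries the lowest of the two numbers in an assay on isolated protein for inhibition of matrix metalloproteinase-9 (Homo sapiens), read by FRET; on this read-out higher numbers stand for weaker inhibition and lower numbers for stronger inhibition; its only neighbour is compound 1, and the single measured step between them, a 3.0-fold lower number from compound 1 to compound 2 (0.47 log units; beyond the scatter), lies beyond the scatter. Both compounds share the same core and differ only on the saturated chain carbon bound to an aromatic carbon.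

Compound 3, `COCCc1cc(COc2ccc([C@]3(N)CCN([C@H](CC(C)C)C(=O)NO)C3=O)cc2)c2ccccc2n1`, has not yet been measured. It differs from compound 2 by methoxymethyl in place of hydrogen on a saturated chain carbon bound to an aromatic carbon; seen one bond further out, methyl becomes 2-methoxyethyl. Within the data shown here, the one step that bears on this change is a 3.0-fold lower number from compound 1 to compound 2 (0.47 log units; beyond the scatter): there, taking a methoxy off the same chain carbon lowered the number by a modest amount. Compound 3 brings a methoxy back onto that chain, one bond further out, so the change runs in the reverse sense of the measured step. A rise of similar or smaller size is therefore expected, a 2.1-fold higher number from compound 2 to compound 3 (0.31 log units; beyond the scatter). Compound 3 is accordingly estimated at 800 nM, with a range of 300 nM to 2500 nM.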

Compound 3, half-maximal inhibitory concentration: 1210 nM
For compound 3 the middle estimate is 1.5-fold (0.18 log units) below the measured one; the range from low to high includes it.
By their numbers in this assay, from the lowest: compound 2; then compounds 1 and 3 (each within the scatter of the next).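

In this assay, methoxymethyl in place of hydrogen on a saturated chain carbon bound to an aromatic carbon gives a 3.1-fold higher number from compound 2 to compound 3 (0.49 log units; beyond the scatter) and leaves the plain methyl chain with the lowest number of the three, beyond the scatter from both methoxy-bearing chains. Methoxymethyl in place of methoxy at the same place gives a 1.0-fold higher number from compound 1 to compound 3 (0.02 log units; within the scatter) and stays within the scatter, so the methoxy-bearing chains read alike whichever of the two lengths carries them, and the rise seen on adding a methoxy does not grow or shrink measurably as the oxygen sits one bond further out. No measurement in hand says why the methyl chain stands apart from these two.

Still open, as far as these compounds go, is whether the oxygen matters at all or whether any chain longer than methyl would give the same number: an ethyl or a propyl chain at this place would separate those two readings. Equally open, from the compounds shown here alone, is how a group of another kind would read on the same carbon, such as an amine, a hydroxyl or a carboxylic acid at the end of the chain.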